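This account rests on a few compounds, and the source may have more. Where it says the series, first, only, none or still open, it means among the compounds named here.

Compound 1 `Cc1cc(Cl)nnc1N1CCN(c2ncccn2)CC1` and compound 2 `Cc1ccnnc1N1CCN(c2ncccn2)CC1` share one core. In a functional assay on BV-2 cells (Mus musculus) for inhibition, read by ELISA, with a stated time of 16 h (a higher number here means a weaker inhibitor, a lower number a stronger inhibitor), compound 1 gives > 100000 nM, a limit of the assay. Compound 2 gives > 100000 nM in this assay, likewise a limit. Between them lies a step that the two limits leave unreadable from compound 1 to compound 2, hydrogen in place of chloro on an aromatic carbon, because of the limit of > 100000 nM in this assay, at which 2 of the 2 values shown sit. Compound 2 thus stands at the limit of this assay, with no number. Compound 3 `Cc1cc(C)c(N2CCN(c3ncccn3)CC2)nn1` differs from compound 2 by methyl in place of hydrogen on an aromatic carbon. Among the measured compounds shown here, no measured step reads, so no step beyond the scatter is expected in this assay, and a step that the limit leaves unreadable from compound 2 to compound 3 is the estimate. Compound 3 is expected at 150000 nM, between 40000 nM and 500000 nM, probably again reported as a limit.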

Compound 3, half-maximal inhibitory concentration: > 100000 nM
Compound 3 ended at the assay's limit; the forecaster's own chance of this, stated with the estimate: 85%; the middle value lies beyond the limit too.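

Compound 3 gives > 100000 nM in this assay, which is a limit. No step among compound 1, compound 2 and compound 3 can be read: the limit of > 100000 nM in this assay, at which 3 of the 3 values shown sit.

The compounds shown leave open whether chloro, hydrogen and methyl on this aromatic carbon differ at all in this assay.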